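Swapping a Ring for a Chain on the Ketone

The compounds below may be only part of what the source reports. "The series", "measured", "known", "first", "only" and "open" are said of these compounds alone.

Compound 1, `COC(=O)C1=C(C)NC(=O)NC1c1ccoc1`, gives 42% in an assay on membranes from HEK293 cells for displacement of a labelled ligand from adenosine receptor A2b (Homo sapiens), read by scintillation counting, with a stated time of 30 min, tested at 1 uM; a lower number here means less inhibition, a higher number more inhibition at the concentration tested (going by the name of the read-out).
Compound 2, `CC(=O)C1=C(C)NC(=O)NC1c1ccoc1`, gives 15%.
Compound 3, `CC1=C(C(=O)C2CC2)C(c2ccoc2)NC(=O)N1`, gives 10%.

Compound 3 stands lowest of the three measured numbers, but its gap to compound 2 lies within the scatter, so the two cannot be ordered; only compound 1 is clearly higher. Compound 4, `CCCC(=O)C1=C(C)NC(=O)NC1c1ccoc1`, differs from compound 3 in one place: propyl in place of cyclopropyl on a carbonyl carbon.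

Three measured steps all sit at the same carbonyl carbon. Replacing methoxy by methyl gave a number 27 percentage points lower from compound 1 to compound 2 (beyond the scatter), and replacing methoxy by cyclopropyl gave a number 32 percentage points lower from compound 1 to compound 3 (beyond the scatter). Both, however, remove methoxy, which compound 4 does not. The closest comparison is the swap between methyl and cyclopropyl, a number 5 percentage points lower from compound 2 to compound 3 (within the scatter), which stayed within the scatter. Moving from cyclopropyl to propyl is a swap of the same kind, so no step beyond the scatter is expected.

Compound 4 is therefore estimated to give 12%, with a range from 0% to 28%. This estimate means an expected step of a number 2 percentage points higher from compound 3 to compound 4 (within the scatter).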

Compound 4, a percentage reported as inhibition, at one concentration (the size of the read-out at that concentration, not a potency): 22%
Compound 4: middle estimate off by 10 percentage points, on the low side, within the range that was stated.
By their numbers in this assay, from the lowest: compounds 3, 2 and 4 (each within the scatter of the next, the first and the last beyond it); then compound 1.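

At this carbonyl carbon, ring and open chain are not interchangeable: with the same count of carbons, a number 12 percentage points higher from compound 3 to compound 4 (beyond the scatter) in this assay, a difference that the earlier swap of methyl for cyclopropyl gave no sign of. Propyl cannot be separated from methyl, with a number 7 percentage points higher from compound 2 to compound 4 (within the scatter), so the longer chain shows no clear gain, and even propyl leaves a gap to the ester, with a number 20 percentage points lower from compound 1 to compound 4 (beyond the scatter), so compound 1 remains clearly above all three ketones. No available evidence explains why the open chain and the ring differ here.

Going by these compounds, it remains open whether a longer chain such as butyl or a branched group such as isopropyl would separate from propyl at this carbonyl carbon. Also open, on these data alone, is whether an amine or ethoxy in this place would match the methoxy of compound 1.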